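Chain extension on the aryl ether of compound 1

The source may report more compounds than this note shows. Statements on the series, on what has been measured and on what is new or still open speak of the compounds shown alone.

Compound 1 `CCCCOc1ccc(-c2c(C)[nH]c(=O)n2C)cc1` is tested in a functional assay on the whole organism with Rattus norvegicus as the target; on this read-out higher numbers stand for an effect only at larger amounts of compound and lower numbers for an effect already at smaller amounts; compound 1 gives 0.3 mg/kg there. Compound 2 `CCCCCCc1ccc(-c2c(C)[nH]c(=O)n2C)cc1` gives 0.3 mg/kg in this assay, so compound 1 is level with compound 2 at the digits measured, and the two together give the highest of the three numbers. Compound 3 `Cc1[nH]c(=O)n(C)c1-c1ccc(C2CCCCC2)cc1` gives 0.1 mg/kg in this assay, the lowest of the three.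

Compound 4 `CCCCCCCCCCOc1ccc(-c2c(C)[nH]c(=O)n2C)cc1` differs from compound 1 in one place: hexyl in place of hydrogen on a saturated chain carbon, four bonds along the chain from an oxygen on an aromatic ring

Going by the values given here, three measured steps bear on this. Exchanging the butoxy of compound 1 for a hexyl, no change at the digits printed from compound 1 to compound 2 (within the scatter), left the number where it was. Putting a cyclohexyl in the same position, a 3.0-fold lower number from compound 1 to compound 3 (0.48 log units; beyond the scatter) and a 3.0-fold lower number from compound 2 to compound 3 (0.48 log units; beyond the scatter), gave a modest lower number. Among the compounds with values here, none of the measured steps lengthens a chain that is already present; the two chain variants, compound 1 and compound 2, sit together, and only the ring variant, compound 3, moves. The step from compound 1 to compound 4 is therefore expected to stay within the scatter or to give a slightly higher number, a 1.7-fold higher number from compound 1 to compound 4 (0.22 log units; within the scatter).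

Compound 4 is accordingly expected to give about 0.5 mg/kg in this assay, with a range from 0.15 mg/kg to 1.5 mg/kg.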

Compound 4, minimum effective dose: 0.1 mg/kg
Estimate against measurement, compound 4: 5.0-fold (0.70 log units) above; measured number outside the range, below it.
By their numbers in this assay, from the lowest: compounds 3 and 4 (each within the scatter of the next); then compounds 1 and 2 (each within the scatter of the next).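

In this assay, hexyl in place of hydrogen on a saturated chain carbon, four bonds along the chain from an oxygen on an aromatic ring, gives a 3.0-fold lower number from compound 1 to compound 4 (0.48 log units; beyond the scatter). This is the only step shown that lengthens a chain already present, and it shows that the number responds to chain length at this position, whereas the exchange of butoxy for hexyl, no change at the digits printed from compound 1 to compound 2 (within the scatter), left it unchanged at the digits printed. Going by these compounds alone, an open chain can thus reach the number that had otherwise been seen only with the cyclohexyl ring: compound 3 gives 0.1 mg/kg and compound 4 gives 0.1 mg/kg; no evidence on the cause of the shift is available.

Still open, as far as these compounds go, is how the number runs through the hexyloxy and octyloxy chains, and whether it holds or turns back with a chain longer than that of compound 4. Also open, from the compounds shown here alone, is how the position tolerates a chain carrying an amine or a carboxylic acid.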